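Lengthening the Sulfur Chain Past the Assay Limit

The compounds below may be only part of what the source reports. "The series", "measured", "known", "first", "only" and "open" are said of these compounds alone.

Three chloromethyl ketones share one core and differ only in the saturated chain attached to the sulfur. Compound 1 `CCCCCSC[C@H](NC(C)=O)C(=O)CCl` gives 5800 nM in a functional assay on NALM-6 cells (Homo sapiens); a higher number here means a weaker inhibitor, a lower number a stronger inhibitor. Compound 2 `CCCCCCSC[C@H](NC(C)=O)C(=O)CCl` gives 3300 nM in this assay. The step of a 1.8-fold lower number from compound 1 to compound 2 (0.24 log units; within the scatter) is small. Compound 3 `CCCCCCCCCCCCCSC[C@H](NC(C)=O)C(=O)CCl` reaches only a limit of the assay, > 100000 nM, so no number is known for it in this assay. Compound 3 thus stands at the weak end of these three, as the limit of > 100000 nM in this assay, at which 1 of the 3 values shown sits, records.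

The untested compound 4 `CCCCCCCCCCCCCCCCCCCCCCSC[C@H](NC(C)=O)C(=O)CCl` carries a still longer chain: nonyl in place of hydrogen on a saturated chain carbon, ten or more bonds along the chain from a sulfur. The measured steps that bear on this are an at least 17-fold higher number from compound 1 to compound 3 (1.23 log units; beyond the scatter) and an at least 30-fold higher number from compound 2 to compound 3 (1.48 log units; beyond the scatter), both large and both beyond the scatter, and both run toward a higher number as the chain lengthens. Adding nonyl continues in the same direction, further out. For the measured compounds named here, no measured step covers a chain longer than that of compound 3, so the size of the step is uncertain, but a weaker result, most likely another limit, is expected. Compound 4 is therefore expected to show 300000 nM in this assay, between 100000 nM and 1000000 nM, an expected step that the limit leaves unreadable from compound 3 to compound 4 that would probably be reported only as a limit again.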

Compound 4, half-maximal inhibitory concentration: > 100000 nM
Compound 4 was reported as a limit; the forecaster's own chance of this, stated with the estimate: 90%; the middle value is on the limit's open side.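

Compound 4 is reported only as a limit in this assay, > 100000 nM. For the compounds shown here, compound 3 is a limit as well, so no step from compound 3 to compound 4 can be read. The compounds shown leave open what true values lie behind these two limits, and at what chain length between compound 2 and compound 3 the large loss of activity begins.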